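Adding a piperidinylmethyl group to the methyl of compound 3

This account rests on a few compounds, and the source may have more. Where it says the series, first, only, none or still open, it means among the compounds named here.

Three close relatives share one core and differ only in the group carried on a saturated chain carbon bound to an aromatic nitrogen. Compound 1 `NC(=O)Cn1c(=O)n(C2OC(CO)[C@@H](O)[C@H]2O)c2nc(N)nc(O)c21` carries a carbamoyl there, compound 2 `CCOC(=O)Cn1c(=O)n(C2OC(CO)[C@@H](O)[C@H]2O)c2nc(N)nc(O)c21` an ethoxycarbonyl, and compound 3 `Cn1c(=O)n(C2OC(CO)[C@@H](O)[C@H]2O)c2nc(N)nc(O)c21` only hydrogen. In a functional assay on the whole organism with Mus musculus as the target (on this read-out lower numbers stand for smaller maximal responses and higher numbers for larger maximal responses), compound 1 gives 72%, compound 2 gives 58%, and compound 3 gives 100%, the highest of the three, with both other compounds lying beyond the scatter below it.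

Compound 4 `Nc1nc(O)c2c(n1)n(C1OC(CO)[C@@H](O)[C@H]1O)c(=O)n2CCN1CCCCC1` is built from compound 3 by the change ((piperidin-1-yl)methyl in place of hydrogen on a saturated chain carbon bound to an aromatic nitrogen). Among the measured compounds shown here, the steps that bear on this are those ending at compound 3: a number 28 percentage points higher from compound 1 to compound 3 (beyond the scatter) and a number 42 percentage points higher from compound 2 to compound 3 (beyond the scatter). Both show that taking a group off this chain carbon raised the response; read backwards, placing a group there lowered it, modestly for the carbamoyl and markedly for the ethoxycarbonyl. The group entering in compound 4 is of a different kind, so the size is uncertain, but a decrease is the expected direction. For compound 4 the expected step is a number 35 percentage points lower from compound 3 to compound 4 (beyond the scatter), a downward move roughly between the two measured ones. Compound 4 is therefore estimated to reach 65%, with a likely range from 40% to 95%.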

Compound 4, largest response reached (reported as maximal response), in percent of the reference or control that the assay uses: 0%
For compound 4 the middle estimate is 65 percentage points above the measured one; measured number below the stated range.
By their numbers in this assay, from the lowest: compound 4; then compound 2; then compound 1; then compound 3.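

In this assay, putting (piperidin-1-yl)methyl on the saturated chain carbon bound to an aromatic nitrogen gives a number 100 percentage points lower from compound 3 to compound 4 (beyond the scatter) and leaves compound 4 at 0% so a group at this place can do far more than trim the response, as the carbamoyl and ethoxycarbonyl did. What enters also matters, not just that something enters: the same place gives a number 72 percentage points lower from compound 1 to compound 4 (beyond the scatter) when the carbamoyl is exchanged for the new group, and a number 58 percentage points lower from compound 2 to compound 4 (beyond the scatter) when the ethoxycarbonyl is exchanged for it, so the new group sits well below both earlier groups. Nothing measured here explains this complete loss of response.

The compounds shown cannot separate the effect of the ring from that of its nitrogen, since a carbon-only cyclohexylmethyl group and an open-chain dimethylaminomethyl group would each keep only one of these two features. On these data alone, it also remains open whether a carboxylic acid or a simple longer alkyl chain on this carbon would fall with the earlier groups or with compound 4.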